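From compound 1 to compound 3: amine exchange

The source may hold more compounds than are shown below. What is called first, only, known or untested is meant among the compounds shown, and "the series" means these compounds.

In a functional assay on Caco-2 cells (Homo sapiens) for inhibition, read by MTT assay, with a stated time of 48 h, tested at 10 uM (a higher number here means more inhibition of growth at the concentration tested, a lower number less inhibition of growth), compound 1 (`Cc1cc(=O)c2c(O)c(CN3CCCC3CO)c(O)c([C@H]3CCN(C)C[C@H]3O)c2o1`) gives 19% and compound 2 (`Cc1cc(=O)c2c(O)c(CN3CCC(c4ccccc4)CC3)c(O)c([C@H]3CCN(C)C[C@H]3O)c2o1`) gives 21% at the single concentration tested. Among the measured compounds shown here, compound 1 therefore stands within the scatter of the only other number available. Compound 3 (`Cc1cc(=O)c2c(O)c(CN(C(C)C)C(C)C)c(O)c([C@H]3CCN(C)C[C@H]3O)c2o1`) has not been measured. It differs from compound 1 by diisopropylamino in place of 2-(hydroxymethyl)pyrrolidin-1-yl on a saturated chain carbon bound to an aromatic carbon. For the measured compounds named here, no measured pair isolates this exchange. In this assay no step beyond the scatter is expected, in either direction. This expectation rests only on compound 1 at 19% and compound 2 at 21%, two values within the scatter of each other. The expected change is a number 3 percentage points higher from compound 1 to compound 3 (within the scatter) and remains small. For compound 3 the estimated value is 22%, with an expected range of 8% to 36% for repeated measurements.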

Compound 3, percent growth inhibition at one concentration: 22%
For compound 3 middle estimate and measured number coincide at the digits printed; the range from low to high includes it.
By their numbers in this assay, from the lowest: compounds 1, 2 and 3 (each within the scatter of the next).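

In this assay the first pair differing in one place reads a number 3 percentage points higher from compound 1 to compound 3 (within the scatter), for diisopropylamino in place of 2-(hydroxymethyl)pyrrolidin-1-yl on a saturated chain carbon bound to an aromatic carbon. The entering group has no ring and no hydrogen-bond donor, and its acceptor count differs from that of the leaving group, yet the two compounds lie within the scatter of each other, so at this position these differences in the amine do not separate the numbers at the single concentration tested. No supporting data are available to explain this reading.

On these data alone, whether any amine at this carbon can move the number beyond the scatter remains open. A morpholin-4-yl group, a piperazin-1-yl group or a carboxylic acid on the same carbon would test this further.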